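This account rests on a few compounds, and the source may have more. Where it says the series, first, only, none or still open, it means among the compounds named here.

Compound 3, `Cc1ccc(N2C(=O)[C@H]3[C@H](ON4[C@@H]3C(=O)N(C)[C@@]43C[C@H](C)CC[C@H]3C(C)C)C2=O)c(C)c1`, gives the lowest of the three numbers measured in a functional assay, read by spectrophotometry, with a stated time of 2 h; a higher number here means a weaker inhibitor, a lower number a stronger inhibitor: compound 3 gives 430 ug/mL. Its nearest neighbour is compound 1, `CC(C)[C@@H]1CC[C@@H](C)C[C@@]12N(C)C(=O)[C@@H]1[C@H]3C(=O)N(c4ccc(Cl)cc4)C(=O)[C@H]3ON12`, for which compound 1 gives 710 ug/mL; the step of a 1.7-fold lower number from compound 1 to compound 3 (0.22 log units; within the scatter). The furthest is compound 2, `COc1ccc(N2C(=O)[C@H]3[C@H](ON4[C@@H]3C(=O)N(C)[C@@]43C[C@H](C)CC[C@H]3C(C)C)C2=O)cc1`, for which compound 2 gives 990 ug/mL; the step of a 2.3-fold lower number from compound 2 to compound 3 (0.36 log units; beyond the scatter). Between the other two, the step of a 1.4-fold higher number from compound 1 to compound 2 (0.14 log units; within the scatter).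

Compound 4, `CC(C)[C@@H]1CC[C@@H](C)C[C@@]12N(C)C(=O)[C@@H]1[C@H]3C(=O)N(c4ccc5ccccc5c4)C(=O)[C@H]3ON12`, differs from compound 3 in one place: naphthalen-2-yl in place of 2,4-dimethylphenyl on an amide-type nitrogen in a ring. Every measured step in this set changes the same aryl group on the same ring nitrogen, and all three were small: two within the scatter and one modest. None of them, however, enlarges the aryl group to a second fused aromatic ring, so the exchange in compound 4 goes somewhat beyond what the measured pairs cover.

On that basis compound 4 is expected to sit close to compound 3 in this assay, with the step of a 1.0-fold higher number from compound 3 to compound 4 (0.02 log units; within the scatter) expected to lie within or only just beyond the scatter, in either direction. The estimate for compound 4 in this assay is 450 ug/mL, with a range from 200 ug/mL to 1000 ug/mL.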

Compound 4, half-maximal inhibitory concentration: 2680 ug/mL
Estimate against measurement, compound 4: 6.0-fold (0.77 log units) below; measured number outside the range, above it.
By their numbers in this assay, from the lowest: compounds 3, 1 and 2 (each within the scatter of the next, the first and the last beyond it); then compound 4.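

Exchanging each single-ring aryl group on this amide-type ring nitrogen for naphthalen-2-yl raised the number in this assay every time, with a 6.2-fold higher number from compound 3 to compound 4 (0.79 log units; beyond the scatter), a 2.7-fold higher number from compound 2 to compound 4 (0.43 log units; beyond the scatter) and a 3.8-fold higher number from compound 1 to compound 4 (0.58 log units; beyond the scatter). The earlier compounds had shown this position only with one six-membered aromatic ring, and their changes gave steps that were within the scatter or modest, so they gave no sign that a second such ring would weaken inhibition. All three new steps lie beyond the scatter, which makes compound 4 the weakest inhibitor of the four in this assay and shows that this position does respond to the aryl group placed on it.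

Nothing given here explains why the second aromatic ring has this effect. Still open, from the compounds shown here alone, is whether the rise belongs to the naphthalen-2-yl group alone or would also appear with naphthalen-1-yl or biphenyl-4-yl, and how the number would respond to an unsubstituted phenyl or to an aryl group carrying an amine or a carboxylic acid.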